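Acetamido-to-amino step across two isomeric cores

The source may report more compounds than this note shows. Statements on the series, on what has been measured and on what is new or still open speak of the compounds shown alone.

Compound 1 `COc1ncc(-c2ccc3nc(NC(C)=O)nn3c2)cc1NS(=O)(=O)c1ccc(F)cc1` carries an acetamido group on its core and in a functional assay on HCT-116 cells (Homo sapiens) for antiproliferative activity, read by MTT assay, with a stated time of 48 h (a higher number here means a weaker inhibitor, a lower number a stronger inhibitor), compound 1 gives 850 nM. Compound 2 `COc1ncc(-c2ccc3nc(N)nn3c2)cc1NS(=O)(=O)c1ccc(F)cc1` differs by hydrogen in place of acetyl on a nitrogen on an aromatic ring and in this assay compound 2 gives 2970 nM; the step of a 3.5-fold higher number from compound 1 to compound 2 (0.54 log units; beyond the scatter). Compound 3 `COc1ncc(-c2ccn3nc(NC(C)=O)nc3c2)cc1NS(=O)(=O)c1ccc(F)cc1` has the same atoms as compound 1 joined differently; the difference between the two cores is not broken down here. In this assay compound 3 gives 1320 nM, which lies within the scatter of compound 1.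

Compound 4 `COc1ncc(-c2ccn3nc(N)nc3c2)cc1NS(=O)(=O)c1ccc(F)cc1` differs from compound 3 by hydrogen in place of acetyl on a nitrogen on an aromatic ring, the same change as from compound 1 to compound 2, at a place described in the same words. Going by the values given here, the step from compound 3 to compound 4 is expected to be a 3.5-fold higher number from compound 3 to compound 4 (0.54 log units; beyond the scatter), resting on the single earlier step of a 3.5-fold higher number from compound 1 to compound 2 (0.54 log units; beyond the scatter). Compound 4 is therefore estimated at 4600 nM, with a range from 2000 nM to 10500 nM.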

Compound 4, half-maximal inhibitory concentration: 820 nM
Beside the measured number, compound 4's estimate is 5.6-fold (0.75 log units) above it, outside the stated range (below it).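

On the core of compound 3, acetamido to amino gives a 1.6-fold lower number from compound 3 to compound 4 (0.21 log units; within the scatter), so the change that costs activity on the core of compound 1 leaves no step beyond the scatter here. In this assay, the effect of this change therefore does not transfer between the two cores: the same change on two cores in this assay, a 3.5-fold higher number (0.54 log units; beyond the scatter) from compound 1 to compound 2 and a 1.6-fold lower number (0.21 log units; within the scatter) from compound 3 to compound 4, 5.6-fold (0.75 log units) apart, beyond the scatter of two such steps
This rests on one pair per core in a single assay, so it shows that the step depends on the core in these four compounds, but not why, nor how any other change would transfer.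

Still open, on these data alone, is whether a longer acyl chain such as propanoyl, or a methyl group, on that nitrogen would separate the two cores in the same way. Also open, as far as these compounds go, is whether a third core would follow either pair.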